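This account rests on a few compounds, and the source may have more. Where it says the series, first, only, none or still open, it means among the compounds named here.

Within the data shown here, compound 1 `CCNc1ccc2c(c1)OC(N)=C(C#N)C2c1cc(Br)c(OC)c(OC)c1` gives 14000000 nM in a functional assay on T47D cells (Homo sapiens) for activation (on this read-out lower numbers stand for an effect already at smaller amounts and higher numbers for an effect only at larger amounts of compound), the lower of the two numbers known so far. Compound 2 `COc1ccc2c(c1)OC(N)=C(C#N)C2c1cccc(Cl)c1` gives 80000000 nM in this assay, a higher number that lies beyond the scatter. Compound 3 `CCNc1ccc2c(c1)OC(N)=C(C#N)C2c1cc(OC)c(OC)c(OC)c1` has not yet been measured; it differs from compound 1 by methoxy in place of bromo on an aromatic carbon. Among the measured compounds shown here, no measured pair shows this change, so the shift is expected to stay small and within the scatter, a 1.4-fold higher number from compound 1 to compound 3 (0.15 log units; within the scatter). Compound 3 is estimated at 20000000 nM, with a range from 4000000 nM to 100000000 nM in this assay.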

Compound 3, half-maximal effective concentration: 49000000 nM
Beside the measured number, compound 3's estimate is 2.5-fold (0.39 log units) below it; low and high end bracket the measured number.
By their numbers in this assay, from the lowest: compound 1; then compounds 3 and 2 (each within the scatter of the next).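

In this assay, the pair gives the first step read across a single change: methoxy in place of bromo, on this aromatic carbon ortho to a methoxy group, gives a 3.5-fold higher number from compound 1 to compound 3 (0.54 log units; beyond the scatter). The step is modest but beyond the scatter, so this position does respond to the change, and here bromo goes with the lower number. No measurement at hand accounts for this step.

Going by these compounds, whether a chloro, a hydroxyl or an amine at this place would give a lower or higher number remains open. So does whether this change keeps its size on other compounds.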